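Trimethoxy chalcone series: removing the nitro group

The source may hold more compounds than are shown below. What is called first, only, known or untested is meant among the compounds shown, and "the series" means these compounds.

Working notes on a small chalcone set. All members share the same trimethoxycinnamoyl fragment and differ in the second aryl ring. Compound 1 `COc1cc(OC)c(OC)cc1/C=C/C(=O)c1cc(OC(C)=O)ccc1OC(C)=O` carries two acetoxy groups, compound 2 `COc1cc(OC)c(OC)cc1/C=C/C(=O)c1cc(Cl)ccc1O` a chlorine and a hydroxyl, compound 3 `COc1cc(OC)c(OC)cc1/C=C/C(=O)c1ccc([N+](=O)[O-])cc1` a nitro group, and compound 4 `COc1cc(OC)c(OC)cc1/C=C/C(=O)c1ccccc1` carries no substituent on that ring and awaits measurement.

In a functional assay on MCF7 cells (Homo sapiens) for inhibition, read by MTT assay, with a stated time of 72 h (on this read-out higher numbers stand for weaker inhibition and lower numbers for stronger inhibition), compound 1 gives 63700 nM. For compound 2 this assay reports only a limit, > 150000 nM. For compound 3 this assay likewise reports only a limit, > 150000 nM. For the measured compounds named here, compound 3 therefore stands at the limit of > 150000 nM in this assay, at which 2 of the 3 values shown sit, and with only one true number in the set, that of compound 1, which is itself weak, no ordering among the three can be read.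

The change from compound 3 to compound 4 is hydrogen in place of nitro on an aromatic carbon. Going by the values given here, no step between measured compounds exists in this set, so nothing measured here tells how large this change is in this assay. Given the weak number for compound 1 and the limits for compound 2 and compound 3, no step beyond the scatter is expected in either direction, and a reading at the limit remains plausible. Compound 4 is expected near 120000 nM, in the range 40000 nM to 300000 nM. This estimate corresponds to an expected step of an at least 1.2-fold lower number from compound 3 to compound 4 (0.09 log units; that floor lies within the scatter).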

Compound 4, half-maximal inhibitory concentration: > 150000 nM
Compound 4 ended at the assay's limit; the forecaster's own chance of this, stated with the estimate: 45%; at least 1.2-fold (0.09 log units) between middle value and limit.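

In this assay compound 4 gives only a limit, > 150000 nM. The steps from compound 3 and from compound 2 to compound 4 cannot be read, because all three values are limits: the limit of > 150000 nM in this assay, at which 3 of the 4 values shown sit.

The compounds shown leave open whether hydrogen in place of nitro changes inhibition at all, and how compound 2, compound 3 and compound 4 rank.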